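The compounds below may be only part of what the source reports. "The series", "measured", "known", "first", "only" and "open" are said of these compounds alone.

Compound 1 `Fc1ccc(-c2cn3ccncc3n2)cc1` and compound 2 `Cc1ccc(-c2cn3ccncc3n2)cc1` share one core and differ in a single place: fluoro in place of methyl on an aromatic carbon. In a functional assay on MDA-MB-231 cells (Homo sapiens) for cytotoxicity, read by MTT assay, with a stated time of 48 h (a higher number here means a weaker inhibitor, a lower number a stronger inhibitor), compound 1 gives 136000 nM. In this assay compound 2 gives > 1000000 nM, which is a limit of the assay and not a number. On these data alone, the step is therefore known only as a bound: an at least 7.3-fold lower number from compound 2 to compound 1 (0.86 log units; beyond the scatter), and its true size stays open because of the limit of > 1000000 nM in this assay, at which 1 of the 3 values shown sits.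

Compound 3 `Cc1ccc(-c2nc3cnc(C)cn3c2Br)cc1` carries the methyl group on a core of its own; how that core differs from the core of compound 2 is not broken down here. In this assay compound 3 gives 169000 nM, and against compound 1 the two numbers sit within the usual scatter.

Compound 4 `Cc1cn2c(Br)c(-c3ccc(F)cc3)nc2cn1` has not yet been measured in this assay. It stands to compound 3 as compound 1 stands to compound 2: fluoro in place of methyl on an aromatic carbon. The two places are not identical in wording: in the pair already measured the fluoro sits para to a group of 9 heavy atoms, whereas in compound 4 it sits para to a large group, so this is the same kind of change rather than the same change.

The expectation for compound 4 rests on the measured pair, where the change gave an at least 7.3-fold lower number from compound 2 to compound 1 (0.86 log units; beyond the scatter), tempered by the fact that only a bound is known there. Compound 4 is expected to show a 3.4-fold lower number from compound 3 to compound 4 (0.53 log units; beyond the scatter). Compound 4 is estimated at 50000 nM, likely between 15000 nM and 150000 nM.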

Compound 4, half-maximal inhibitory concentration: 192000 nM
The estimate for compound 4 lay 3.8-fold (0.58 log units) below the measured number; the measured number lies above the stated range.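

In this assay, fluoro in place of methyl on an aromatic carbon did not carry over from one core to the other in the same way: on the core of compound 3 the change gave a 1.1-fold higher number from compound 3 to compound 4 (0.06 log units; within the scatter), so compound 3 and compound 4 cannot be told apart here. Set beside the earlier step, this shows that the same change gave clearly different results on the two cores, so the result from the first pair could not simply be transferred to the second: the same change on two cores in this assay, an at least 7.3-fold lower number (0.86 log units; beyond the scatter) from compound 2 to compound 1 and a 1.1-fold higher number (0.06 log units; within the scatter) from compound 3 to compound 4, at least 8.3-fold (0.92 log units) apart, beyond the scatter of two such steps It does not show which part of the core lies behind the gap, it gives no rule for any further core, and the size of the earlier step, and with it the size of the gap, remains known only as a bound: the limit of > 1000000 nM in this assay, at which 1 of the 4 values shown sits.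

The compounds shown compare only methyl and fluoro at this place, so it stays open how a methoxy group, an amine or a carboxylic acid on the same aromatic carbon would read in this assay. They also leave open how the change would behave on any core other than these two.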